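Extending the propyl chain of a vinyl ketone by one carbon

This account rests on a few compounds, and the source may have more. Where it says the series, first, only, none or still open, it means among the compounds named here.

Compound 2, `C=CC(=O)c1ccc(CCC)cc1`, is the weaker of the two measured compounds. In an in vitro assay on BL21-DE3 cells for displacement of a labelled ligand from thyroid hormone receptor beta (Homo sapiens), read by fluorescence polarization (a higher number here means a weaker inhibitor, a lower number a stronger inhibitor), compound 2 gives 100000 nM. For the measured compounds named here, the only other measured compound, compound 1, `CCCCCCc1ccc(C(=O)CCN(C(C)C)C(C)C)cc1`, differs from it at both ends of the molecule and gives 2000 nM in this assay, a gap that is stated to lie beyond the scatter of repeated measurements; since compound 1 changes more than one place at once, its value shows only that far stronger binding is reachable, not which part of the molecule is responsible.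

Compound 3, `C=CC(=O)c1ccc(CCCC)cc1`, keeps the vinyl ketone of compound 2 and changes a single place: methyl in place of hydrogen on a saturated chain carbon, three bonds along the chain from an aromatic carbon. Going by the values given here, no measured pair with exactly this change exists here, so the direction is inferred only loosely from the longer chain of compound 1. The author expects the step from compound 2 to compound 3 in this assay to be a modest improvement, a 2.0-fold lower number from compound 2 to compound 3 (0.30 log units; within the scatter), which could still fall within the scatter. Compound 3 is therefore estimated at 50000 nM, with a range from 15000 nM to 150000 nM.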

Compound 3, half-maximal inhibitory concentration: 66000 nM
Estimate against measurement, compound 3: 1.3-fold (0.12 log units) below; the range from low to high includes it.
By their numbers in this assay, from the lowest: compound 1; then compounds 3 and 2 (each within the scatter of the next).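

In this assay, for the compounds shown here, the first single-place step reads a 1.5-fold lower number from compound 2 to compound 3 (0.18 log units; within the scatter), so going from propyl to butyl on the vinyl ketone does not separate compound 2 and compound 3. At this place, on a saturated chain carbon, three bonds along the chain from an aromatic carbon, one added methyl therefore produces neither a gain nor a loss that can be claimed, and this single step does not establish any trend with chain length. No independent measurement bears on this result, so the data offer no explanation for the size of the step.

Going by these compounds, it remains open whether a longer chain on the vinyl ketone, such as pentyl or hexyl, would move the number beyond the scatter, which would begin to separate the contribution of the chain in compound 1 from that of the other end of the molecule. On these data alone, it is equally open whether a different group at this place, such as a hydroxyl or a carboxylic acid, would change the reading where a methyl does not.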